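Phenyl for pyrrolidinyl on the pyrrolopyrimidine-type core

The source may report more compounds than this note shows. Statements on the series, on what has been measured and on what is new or still open speak of the compounds shown alone.

Compound 1 `Cn1c(N2CCCC2)c(C#N)c2c(N)ncnc21`: in an assay on isolated protein for inhibition of Leucine-rich repeat serine/threonine-protein kinase 2 (Homo sapiens), read by TR-FRET and LanthaScreen, with stated times of 50 min and 30 min, in the presence of a further agent that is not named here (on this read-out higher numbers stand for weaker inhibition and lower numbers for stronger inhibition), compound 1 gives 1480 nM.
Compound 2 `Cc1nn(C2CCOC2)cc1Nc1nc(N)c2c(C#N)c(N3CCC[C@H]3C)n(C)c2n1`: in this assay compound 2 gives 19 nM; 44 nM (2 entries), shown as the several entries of compound 2 in this assay, 19 nM; 44 nM (2 entries).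

Within the data shown here, compound 1 holds the only single number of its own in this assay; one further entry gives no single number. Compound 3 `Cn1c(-c2ccccc2)c(C#N)c2c(N)ncnc21` carries phenyl in place of pyrrolidin-1-yl on an aromatic carbon. Among the measured compounds shown here, no measured pair shows this change, so any step is an expectation only. Compound 3 is expected near compound 1, with the estimated step of a 1.4-fold higher number from compound 1 to compound 3 (0.13 log units; within the scatter) not clearly beyond the scatter. Compound 3 is estimated at 2000 nM, within 400 nM to 10000 nM.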

Compound 3, half-maximal inhibitory concentration: 1260 nM
Beside the measured number, compound 3's estimate is 1.6-fold (0.20 log units) above it; measured number inside the range.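

In this assay, phenyl in place of pyrrolidin-1-yl on an aromatic carbon gives a 1.2-fold lower number from compound 1 to compound 3 (0.07 log units; within the scatter). At this position, a five-membered non-aromatic ring and a six-membered aromatic ring of carbon only therefore cannot be told apart on the core of compound 1, even though only pyrrolidin-1-yl carries a hydrogen-bond acceptor. Repeat entries elsewhere in the series also spread: the several entries of compound 2 in this assay, 19 nM; 44 nM (2 entries)

Going by these compounds, whether phenyl and pyrrolidin-1-yl also read alike on the more elaborate core of compound 2 remains open. Also open, on these data alone, is how a morpholin-4-yl ring or a phenyl bearing a carboxylic acid would read at this position.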